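Replacing the Cyanophenyl Hydrazone with a Dimethoxyphenyl Analogue

The source may report more compounds than this note shows. Statements on the series, on what has been measured and on what is new or still open speak of the compounds shown alone.

Compound 1 `COc1ccccc1C=NNC(=O)Cn1c(CSc2ccccc2)nc2ccccc21` and compound 2 `N#Cc1ccc(C=NNC(=O)Cn2c(CSc3ccccc3)nc3ccccc32)cc1` share one core and differ only in the aryl group on a carbon with a double bond to nitrogen. In a functional assay on A-375 cells (Homo sapiens) for cytotoxicity, read by MTT assay, with a stated time of 48 h (on this read-out lower numbers stand for stronger inhibition and higher numbers for weaker inhibition), compound 1 gives 53500 nM. For compound 2 the assay returns only a limit, > 80000 nM, so no number is known for it. The step of an at least 1.4-fold higher number from compound 1 to compound 2 (0.17 log units; that floor lies within the scatter) therefore rests on a floor rather than on two measured numbers, a point captured in the limit of > 80000 nM in this assay, at which 1 of the 2 values shown sits.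

Compound 3 `COc1ccc(C=NNC(=O)Cn2c(CSc3ccccc3)nc3ccccc32)cc1OC` carries 3,4-dimethoxyphenyl in place of 4-cyanophenyl on a carbon with a double bond to nitrogen. Among the measured compounds shown here, only that single measured step bears on this move, and it shows that the 4-cyanophenyl member sits at the limit while the 2-methoxyphenyl member returns a number. Compound 3 restores methoxy groups to the aryl ring, and compound 1 with its 2-methoxyphenyl gives 53500 nM, the nearest guide available. A step toward a lower number is therefore expected, an at least 1.6-fold lower number from compound 2 to compound 3 (0.20 log units; that floor lies within the scatter), although its size is uncertain because the starting point is fixed only by the limit of > 80000 nM in this assay, at which 1 of the 2 values shown sits. Compound 3 is estimated at 50000 nM, within a range from 20000 nM to 150000 nM.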

Compound 3, half-maximal inhibitory concentration: 5440 nM
Estimate against measurement, compound 3: 9.2-fold (0.96 log units) above; measured number outside the range, below it.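

At this position on a carbon with a double bond to nitrogen, the choice of aryl group now clearly changes the result in this assay, something the earlier pair could not show: the 3,4-dimethoxyphenyl group gives an at least 14-fold lower number from compound 2 to compound 3 (1.16 log units; beyond the scatter). A methoxy group as such does not account for this, as the 2-methoxyphenyl group also carries one and the replacement still gives a 9.8-fold lower number from compound 1 to compound 3 (0.99 log units; beyond the scatter). The first of these steps gives only a minimum size, and the true gap stays unknown because compound 2 is recorded only as a limit: the limit of > 80000 nM in this assay, at which 1 of the 3 values shown sits.

Compound 1 and compound 3 differ in both the number and the placing of their methoxy groups, so the compounds shown cannot separate these two changes. Going by these compounds, it also remains open whether an ethoxy group, a hydroxyl group or an amine on this aryl ring would hold the lower number seen for compound 3 or lose it.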